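This account rests on a few compounds, and the source may have more. Where it says the series, first, only, none or still open, it means among the compounds named here.

Working notes on the series. In a functional assay on Jurkat cells (Homo sapiens) for antiproliferative activity, read by MTT assay, with a stated time of 48 h (a higher number here means a weaker inhibitor, a lower number a stronger inhibitor), compound 1 `O=C(CCCCCCn1cc(Nc2ncc(Cl)c(Nc3cccc(Cl)c3)n2)cn1)NO` gives 100 nM, compound 2 `COc1ccc(Nc2nc(Nc3cnn(CCCCCCC(=O)NO)c3)ncc2Cl)cc1` gives 130 nM and compound 3 `CNc1nc(Nc2cnn(CCCCCCC(=O)NO)c2)ncc1Cl` gives 70 nM. Compound 3 has no separate place among these numbers, since all three values lie within the scatter of one another. Compound 4 `O=C(CCCCCCn1cc(Nc2ncc(Cl)c(Nc3ccc(F)cc3)n2)cn1)NO` has 4-fluorophenyl in place of methyl on a nitrogen on an aromatic ring.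

Two measured steps exchange a substituted phenyl and methyl at this same place, though in the opposite direction. These are a 1.4-fold lower number from compound 1 to compound 3 (0.15 log units; within the scatter) and a 1.9-fold lower number from compound 2 to compound 3 (0.27 log units; within the scatter), and both stay within the scatter. Exchanging one substituted phenyl for the other gives a 1.3-fold higher number from compound 1 to compound 2 (0.11 log units; within the scatter), also within the scatter. Among the compounds with values here, no measured compound carries 4-fluorophenyl, so the estimate rests on these three steps alone. In this assay, on these data alone, no change beyond the scatter is therefore expected, and the direction stays open. The expected size is a 1.4-fold higher number from compound 3 to compound 4 (0.15 log units; within the scatter). For compound 4 the estimated value is 100 nM, with an expected range of 50 nM to 200 nM.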

Compound 4, half-maximal inhibitory concentration: 120 nM
Compound 4: middle estimate off by 1.2-fold (0.08 log units), on the low side; low and high end bracket the measured number.
By their numbers in this assay, from the lowest: compounds 3, 1, 4 and 2 (each within the scatter of the next).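

In this assay 4-fluorophenyl on this nitrogen joins 3-chlorophenyl and 4-methoxyphenyl in staying within the scatter of methyl, with a 1.7-fold higher number from compound 3 to compound 4 (0.23 log units; within the scatter) for this exchange. Among the substituted phenyl groups, fluoro in place of methoxy gives a 1.1-fold lower number from compound 2 to compound 4 (0.03 log units; within the scatter) and the change from 3-chlorophenyl to 4-fluorophenyl gives a 1.2-fold higher number from compound 1 to compound 4 (0.08 log units; within the scatter) as its step, so the new substituent separates no compound from the others. Across these four compounds, a group of one heavy atom and a group of seven at this place therefore remain within the scatter, and none of the compounds goes against this.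

Nothing at hand explains this flat result. Still open, on these data alone, is whether an amine or a carboxylic acid on the ring of the group at this nitrogen, or a longer chain in place of the chain on the shared core, would give a step beyond the scatter.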